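A few compounds are considered here, and "the series" means these few. Any claim that something is new, unique, unknown or untested is made for them only; others in the source may bear on it.

Three compounds have been measured in a functional assay on CCRF-CEM cells (Homo sapiens) for inhibition, read by sulforhodamine B assay, with a stated time of 48 h, tested at 10 uM; on this read-out higher numbers stand for more inhibition at the one concentration tested (going by the name of the read-out) and lower numbers for less inhibition:

Compound 1 `c1ccc(-c2cn3ccnc3c(-c3ccc4ncn(C5CCCCC5)c4c3)n2)cc1` gives 81.3%.
Compound 2 `c1cn2cc(-c3ccsc3)nc(-c3ccc4ncn(C5CCCCC5)c4c3)c2n1` gives 29.2%.
Compound 3 `Fc1ccccc1-c1cn2ccnc2c(-c2ccc3ncn(C4CCCCC4)c3c2)n1` gives 22.5%.

Compound 3 stands at the low end of these numbers. The step of a number 58.8 percentage points lower from compound 1 to compound 3 (beyond the scatter) is beyond the usual scatter, whereas a number 6.7 percentage points lower from compound 2 to compound 3 (within the scatter) lies within it, so compound 3 and compound 2 cannot be told apart on this read-out.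

Compound 4 `FC(F)(F)c1cccc(-c2cn3ccnc3c(-c3ccc4ncn(C5CCCCC5)c4c3)n2)c1` differs from compound 3 by 3-(trifluoromethyl)phenyl in place of 2-fluorophenyl on an aromatic carbon. Within the data shown here, no measured step swaps one substituted phenyl for another, so there is no direct guide. The steps that come closest are a number 58.8 percentage points lower from compound 1 to compound 3 (beyond the scatter) and a number 52.1 percentage points lower from compound 1 to compound 2 (beyond the scatter), both large drops from the plain phenyl of compound 1, which show that this position is sensitive to change but give no direction for a trifluoromethyl group. Compound 4 is therefore expected to land between the two extremes seen so far, with a wide range, as a step of a number 15.5 percentage points higher from compound 3 to compound 4 (beyond the scatter). The estimate for compound 4 is 38%, between 10% and 75%.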

Compound 4, a percentage reported as inhibition, at one concentration (the size of the read-out at that concentration, not a potency): 27.3%
Estimate against measurement, compound 4: 10.7 percentage points above; the measured number falls inside the stated range.
By their numbers in this assay, from the lowest: compounds 3, 4 and 2 (each within the scatter of the next); then compound 1.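

In this assay, trifluoromethyl in place of hydrogen on the phenyl ring of compound 1 gives a number 54 percentage points lower from compound 1 to compound 4 (beyond the scatter), so a substituted phenyl ring as well as the swaps seen earlier loses most of the inhibition. The other two steps, a number 4.8 percentage points higher from compound 3 to compound 4 (within the scatter) and a number 1.9 percentage points lower from compound 2 to compound 4 (within the scatter), place the 3-(trifluoromethyl)phenyl, 2-fluorophenyl and thiophen-3-yl compounds at one low level, leaving the plain phenyl of compound 1 the only group shown here that keeps high inhibition. No measurement available here explains why these three groups cannot be told apart or why the plain phenyl stands out.

Still open, on these data alone, is whether any substituent on this phenyl ring can keep the inhibition, for instance a methyl or methoxy group, an amine or a carboxylic acid. A ring containing nitrogen, such as pyridine, in place of the phenyl is equally untested among the compounds shown.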